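The source may hold more compounds than are shown below. What is called first, only, known or untested is meant among the compounds shown, and "the series" means these compounds.

Compound 2, `CC(C)(O)c1cn(-c2ccnc3cc(Cl)ccc23)nn1`, sits at the lower end of the two numbers in hand: in an ADME assay on HepG2 cells (Homo sapiens) for cytotoxicity, read by MTT assay, with a stated time of 24 h (on this read-out lower numbers stand for higher toxicity in this test and higher numbers for lower toxicity in this test), compound 2 gives 442000 nM, while compound 1, `Clc1ccc2c(-n3cc(-c4ccccc4)nn3)ccnc2c1`, gives 574000 nM in this assay, and the gap a 1.3-fold lower number from compound 1 to compound 2 (0.11 log units; within the scatter) is within the scatter. Compound 3, `CCN(CC)Cc1cn(-c2ccnc3cc(Cl)ccc23)nn1`, is reached through ((diethylamino)methyl in place of 1-hydroxy-1-methylethyl on an aromatic carbon). Going by the values given here, the only measured step, which changed the same position, moved the number by a 1.3-fold lower number from compound 1 to compound 2 (0.11 log units; within the scatter), so no step beyond the scatter is expected here. Compound 3 is therefore estimated at 350000 nM in this assay, within 150000 nM to 800000 nM. The expected step is a 1.3-fold lower number from compound 2 to compound 3 (0.10 log units; within the scatter).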

Compound 3, half-maximal cytotoxic concentration: 1850000 nM
For compound 3 the middle estimate is 5.3-fold (0.72 log units) below the measured one; the measured number lies above the stated range.
By their numbers in this assay, from the lowest: compounds 2 and 1 (each within the scatter of the next); then compound 3.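

In this assay, the group on this aromatic carbon turns out to matter: putting (diethylamino)methyl there gives a change beyond the scatter against both earlier groups (a 4.2-fold higher number from compound 2 to compound 3 (0.62 log units; beyond the scatter); a 3.2-fold higher number from compound 1 to compound 3 (0.51 log units; beyond the scatter)). Going by these compounds alone, the earlier swap between phenyl and 1-hydroxy-1-methylethyl had stayed within the scatter, so only this third group reveals that the position can shift the number, here towards lower toxicity in this test. Nothing available explains the shift. Going by these compounds, the upward move rests on a single amine, so it remains open whether a smaller one, such as (dimethylamino)methyl, or a carboxylic acid at this position would move the number the same way.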